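Swapping nitro for iodo on a pyrazole-linked phenyl ring

This account rests on a few compounds, and the source may have more. Where it says the series, first, only, none or still open, it means among the compounds named here.

Measured so far:
- compound 1, `O=[N+]([O-])c1ccc(-c2nn(-c3ccccc3)cc2C(Nc2nc3ccccc3s2)c2c(O)ccc3ccccc23)cc1`: 14700 nM in a functional assay on MCF7 cells (Homo sapiens) for antiproliferative activity, read by MTT assay, with a stated time of 48 h; a higher number here means a weaker inhibitor, a lower number a stronger inhibitor
- compound 2, `Oc1ccc2ccccc2c1C(Nc1nc2ccccc2s1)c1cn(-c2ccccc2)nc1-c1ccc(I)cc1`: 18900 nM in this assay
- compound 3, `COc1ccc2nc(NC(c3cn(-c4ccccc4)nc3-c3cccc([N+](=O)[O-])c3)c3c(O)ccc4ccccc34)sc2c1`: 26800 nM in this assay

Compound 1 and compound 2 share one core and differ in one place: iodo in place of nitro on an aromatic carbon. That change gave a 1.3-fold higher number from compound 1 to compound 2 (0.11 log units; within the scatter), so the two values are indistinguishable within the usual scatter of this assay. Compound 3 carries a different core; the difference between the core of compound 1 and the core of compound 3 is not broken down here. Its value in this assay lies within the scatter of both compound 1 and compound 2, so no order among the three can be read from these numbers.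

Compound 4, `COc1ccc2nc(NC(c3cn(-c4ccccc4)nc3-c3cccc(I)c3)c3c(O)ccc4ccccc34)sc2c1`, is not yet measured. It differs from compound 3 in one place: iodo in place of nitro on an aromatic carbon. Among the measured compounds shown here, this is the same kind of change as the one from compound 1 to compound 2, but not the same: in the earlier pair the group sits para to a large group, here it sits meta to a large group.

For compound 4 in this assay a step of a 1.2-fold higher number from compound 3 to compound 4 (0.08 log units; within the scatter) is expected, resting on the step seen from compound 1 to compound 2, which gave a 1.3-fold higher number from compound 1 to compound 2 (0.11 log units; within the scatter), and on the single core difference that is not broken down here. Compound 4 is therefore estimated at 32000 nM, with a likely range from 15000 nM to 65000 nM.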

Compound 4, half-maximal inhibitory concentration: 20000 nM
The estimate for compound 4 lay 1.6-fold (0.20 log units) above the measured number; low and high end bracket the measured number.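

In this assay, putting iodo in place of nitro on the second core gave a 1.3-fold lower number from compound 3 to compound 4 (0.13 log units; within the scatter), so these two values cannot be told apart. Set beside the same change on the first core, this step gives no sign that the outcome depends on the core: the same change on two cores in this assay, a 1.3-fold higher number (0.11 log units; within the scatter) from compound 1 to compound 2 and a 1.3-fold lower number (0.13 log units; within the scatter) from compound 3 to compound 4, 1.7-fold (0.24 log units) apart, within the scatter of two such steps. This shows only that, in these two pairs, the swap from nitro to iodo left the number within the usual scatter; it does not show that the two groups are interchangeable across this series. Two pairs are too few to support a general rule, a small real effect could be hidden in the scatter, and the pairs also differ in where the group sits on the ring.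

On this phenyl ring the compounds shown carry only nitro and iodo, so it remains open whether a different group there, such as an amine or a carboxylic acid, would move the number beyond the scatter. Among the compounds shown here, also open is what the core difference itself contributes, as compound 1 and compound 3 differ in more than one place and no single-change pair separates those differences.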